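The compounds below may be only part of what the source reports. "The series", "measured", "known", "first", "only" and "open" are said of these compounds alone.

Of the compounds shown here, three have so far been measured in an assay on CHO cells with metabotropic glutamate receptor 2 (Homo sapiens) as the target, read by FLIPR; a lower number here means that less compound is needed, a higher number that more compound is needed for the effect. Compound 1 `Cn1c(CN2CCN(c3nc(Cl)ccc3C(F)(F)F)CC2)nc2cc(C(F)(F)F)ccc21` gives 2000 nM. Compound 2 `CCCn1c(CN2CCN(c3ncc(Cl)cn3)CC2)nc2ccccc21` gives 794 nM. Compound 3 `Cn1c(CN2CCN(c3nc4ccccc4s3)CC2)nc2ccccc21` gives 316 nM. Compound 2 therefore stands second highest of the three numbers: its nearest neighbour is compound 3, whose number is lower by more than the usual scatter, and its furthest is compound 1, whose number is higher by more than the usual scatter.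

Compound 4 `Clc1cnc(N2CCN(Cc3nc4ccccc4n3Cc3ccccc3)CC2)nc1` has not yet been measured. It differs from compound 2 in a single place: phenyl in place of ethyl on a saturated chain carbon bound to an aromatic nitrogen. Among the measured compounds shown here, no pair of measured compounds differs only in this way, so nothing measured shows directly what this change does to the number, and the other measured compounds differ from compound 2 in other places as well. The step expected from compound 2 to compound 4 is a 1.6-fold lower number from compound 2 to compound 4 (0.20 log units; within the scatter), a modest move towards a lower number that may not clearly exceed the scatter. Compound 4 is accordingly estimated at 500 nM, with a range from 150 nM to 1600 nM.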

Compound 4, half-maximal effective concentration: 126 nM
Estimate against measurement, compound 4: 4.0-fold (0.60 log units) above; the whole stated range lies above it.
By their numbers in this assay, from the lowest: compound 4; then compound 3; then compound 2; then compound 1.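

In this assay, phenyl in place of ethyl on a saturated chain carbon bound to an aromatic nitrogen gives a 6.3-fold lower number from compound 2 to compound 4 (0.80 log units; beyond the scatter) and so moves the number by more than the usual scatter. The same difference, read as propyl to benzyl, shows directly that this position affects the number and that a six-membered aromatic ring of carbon only can stand there with less compound needed for the effect. Nothing at hand explains why this change lowers the number.

On these data alone, this single pair cannot separate the effect of the ring from that of the larger group, and a longer chain such as butyl, or a benzyl carrying a fluorine or a methoxy group, remains open. As far as these compounds go, whether the same change would give a similar step in compounds that differ elsewhere, such as compound 3, also remains open.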